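The source may report more compounds than this note shows. Statements on the series, on what has been measured and on what is new or still open speak of the compounds shown alone.

Compound 2, `c1ccc2ncc(-c3nn[nH]n3)cc2c1`, carries no substituent on the carbon ring of its shared core. In a functional assay on the whole organism (strain Sprague-Dawley) for inhibition, with Rattus norvegicus as the target (on this read-out lower numbers stand for an effect already at smaller amounts and higher numbers for an effect only at larger amounts of compound), compound 2 gives 25 mg/kg, and compound 1, `FC(F)(F)c1ccc2cc(-c3nn[nH]n3)cnc2c1`, which bears trifluoromethyl on an aromatic carbon, gives 25 mg/kg. Compound 2 thus stands level with compound 1 at the digits shown, since no change at the digits printed from compound 1 to compound 2 (within the scatter). Compound 3, `COc1ccc2cc(-c3nn[nH]n3)cnc2c1`, carries methoxy on the same aromatic carbon. For compound 3 the assay reports only a limit, > 25 mg/kg, and not a number. Accordingly a number no lower from compound 2 to compound 3 (the limit leaves the size open), and likewise a number no lower from compound 1 to compound 3 (the limit leaves the size open); both of these rest on (the limit of > 25 mg/kg in this assay, at which 1 of the 3 values shown sits).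

Compound 4, `Fc1ccc2ncc(-c3nn[nH]n3)cc2c1`, differs from compound 2 by a single change: fluoro in place of hydrogen on an aromatic carbon. Among the measured compounds shown here, the steps that bear on this change are the hydrogen-to-trifluoromethyl step, which lay within the scatter, and the hydrogen-to-methoxy step, whose size is left open by the limit. Fluoro in place of hydrogen on an aromatic carbon is a smaller change than either of those, and no measured step at this position has shown a clear shift in either direction. The expected step is therefore no change at the digits printed from compound 2 to compound 4 (within the scatter), no change beyond the scatter. Compound 4 is estimated at 25 mg/kg, within a range from 12 mg/kg to 50 mg/kg.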

Compound 4, minimum effective dose: 50 mg/kg
For compound 4 the middle estimate is 2.0-fold (0.30 log units) below the measured one; measured number inside the range.
By their numbers in this assay, from the lowest: compounds 1, 2 and 4 (each within the scatter of the next).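

Replacing hydrogen with fluoro on this aromatic carbon, in the position described as meta to a fused ring and para to a fused ring, gives a 2.0-fold higher number from compound 2 to compound 4 (0.30 log units; within the scatter) in this assay. This adds a single fluorine atom to the evidence on the carbon ring of the shared core, and the step stays within the scatter, so this read-out does not separate compound 4 from the unsubstituted compound 2. Nothing shown here gives a reason for this small step, and the only limit among the values concerns a different compound.

Compound 3 has only a limit, > 25 mg/kg, so the size of its steps cannot be read and the effect of methoxy remains undefined. Among the compounds shown here, no step among the compounds with numerical values lies beyond the scatter, leaving open whether a group of another kind on this carbon, such as an amine, a carboxylic acid, chloro or a longer chain, would move the minimum effective dose clearly away from that of compound 2.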